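The source may report more compounds than this note shows. Statements on the series, on what has been measured and on what is new or still open speak of the compounds shown alone.

Compound 1 `Oc1ccc(-c2cc(-c3ccc(O)cc3)nc(-c3ccc(O)cc3)c2)cc1` gives 5120 nM. Compound 2 `Oc1ccc(-c2cc(-c3ccccc3O)cc(-c3ccccc3O)n2)cc1` gives 8240 nM. Compound 3 `Oc1ccc(-c2cc(-c3cccc(O)c3)nc(-c3ccccc3O)c2)cc1` gives 5830 nM.

In a functional assay on HCT-15 cells (Homo sapiens) for cytotoxicity, read by CCK-8 assay, with a stated time of 4 days (a higher number here means a weaker inhibitor, a lower number a stronger inhibitor), the three measured compounds lie close together. Compound 3 stands second highest of the three numbers, with compound 1 as its nearest neighbour and compound 2 as its furthest, and both of those gaps fall within the usual scatter, so no order among them can be claimed.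

Compound 4 `Oc1ccc(-c2cc(-c3cccc(O)c3)nc(-c3cccc(O)c3)c2)cc1` differs from compound 3 in one place: 3-hydroxyphenyl in place of 2-hydroxyphenyl on an aromatic carbon.

Within the data shown here, with no measured step of this kind to draw on, and since all three measured values sit within the scatter of one another, the expected step from compound 3 to compound 4, a 1.0-fold lower number from compound 3 to compound 4 (0.02 log units; within the scatter), is none beyond the scatter. Compound 4 is therefore estimated at 5600 nM, expected within 2500 nM to 12500 nM.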

Compound 4, half-maximal inhibitory concentration: 3810 nM
The estimate for compound 4 lay 1.5-fold (0.17 log units) above the measured number; the range from low to high includes it.
By their numbers in this assay, from the lowest: compounds 4, 1, 3 and 2 (each within the scatter of the next, the first and the last beyond it).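

Among these compounds, this is the first step in this assay between compounds that differ in one place: with 3-hydroxyphenyl in place of 2-hydroxyphenyl on the aromatic carbon next to the ring nitrogen, the step is a 1.5-fold lower number from compound 3 to compound 4 (0.18 log units; within the scatter). At this position, the assay therefore does not separate these two hydroxyphenyl groups. No measurement bearing on this step is available to explain it.

From the compounds shown here alone, it remains open whether a methoxyphenyl or aminophenyl group at this position would give a number beyond the scatter of compound 3. Going by these compounds, the same exchange on the other aromatic carbons of the core also remains untested by these compounds.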